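This account rests on a few compounds, and the source may have more. Where it says the series, first, only, none or still open, it means among the compounds named here.

Measured so far in an assay on HeLa cells for inhibition of sphingosine-1-phosphate transporter SPNS2 (Mus musculus), read by LC-MS, tested at 2 uM; a higher number here means more inhibition at the concentration tested (going by the name of the read-out), a lower number less inhibition:
compound 1 `CCCCCCCCCCc1ccc(-c2noc(CCCNC)n2)cc1` gives 45%
compound 2 `CCCCCCCCCCc1ccc(-c2noc(C(Cl)CCN)n2)cc1` gives 5%

Going by the values given here, compound 2 stands lowest of the two numbers; the one step known, a number 40 percentage points lower from compound 1 to compound 2 (beyond the scatter), runs on the same aromatic carbon that compound 3 alters. Compound 3 `CCCCCCCCCCc1ccc(-c2noc(CCCN3CCCCC3)n2)cc1` is not yet measured; the change is a group of 9 heavy atoms (8 carbon, 1 nitrogen; one six-membered non-aromatic ring with 1 hetero atom) in place of a group of 5 heavy atoms (3 carbon, 1 nitrogen, 1 chlorine; no ring), on an aromatic carbon. The entering group resembles the tertiary-free amine side of compound 1 more than the chlorine-bearing group it replaces, so a step back in the direction of compound 1 is expected, of size a number 35 percentage points higher from compound 2 to compound 3 (beyond the scatter). Compound 3 is expected to give 40%, within 15% to 65%.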

Compound 3, a percentage reported as inhibition, at one concentration (the size of the read-out at that concentration, not a potency): 0%
Estimate against measurement, compound 3: 40 percentage points above, outside the stated range (below it).
By their numbers in this assay, from the lowest: compounds 3 and 2 (each within the scatter of the next); then compound 1.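

In this assay, piperidin-1-yl at the chain end does not keep the level seen with methylamino: a number 45 percentage points lower from compound 1 to compound 3 (beyond the scatter). The 3-(piperidin-1-yl)propyl group and the chlorine-bearing group it replaces cannot be told apart here, a number 5 percentage points lower from compound 2 to compound 3 (within the scatter), so a chain ending in an amine is not enough on its own. No measurement at hand accounts for either step.

Open, as far as these compounds go, is whether a smaller end group on the same propyl chain, such as dimethylamino, pyrrolidin-1-yl or a primary amine, holds the level of compound 1.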